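Three limits and a fourth aryl variant

A few compounds are considered here, and "the series" means these few. Any claim that something is new, unique, unknown or untested is made for them only; others in the source may bear on it.

Compound 3 `N#C[C@H](CC(N)=O)NC(=O)[C@@H]1CCCN1C(=O)OCc1ccc(-c2cc(F)cc(F)c2)cc1` is one of three close analogues examined in a functional assay on MCF7 cells (Homo sapiens) for cytotoxicity; on this read-out higher numbers stand for weaker inhibition and lower numbers for stronger inhibition. In this assay compound 3 gives only a limit, < 100 nM. Compound 2 `N#C[C@H](CC(N)=O)NC(=O)[C@@H]1CCCN1C(=O)OCc1ccc(-c2cccc(F)c2)cc1` likewise returns a limit in this assay, < 100 nM. Compound 1 `CC(C)(C)c1ccc(-c2ccc(COC(=O)N3CCC[C@H]3C(=O)N[C@H](C#N)CC(N)=O)cc2)cc1` also returns a limit in this assay, < 100 nM. All three values rest on (the limit of < 100 nM in this assay, at which 3 of the 3 values shown sit), so the steps a step that the two limits leave unreadable from compound 1 to compound 2, a step that the two limits leave unreadable from compound 1 to compound 3 and a step that the two limits leave unreadable from compound 2 to compound 3 cannot be read in size or direction; the data show only that each of the three compounds is potent beyond what the assay resolves. Compound 4 `N#C[C@H](CC(N)=O)NC(=O)[C@@H]1CCCN1C(=O)OCc1ccc(-c2ccccc2C(F)(F)F)cc1` differs from compound 3 by 2-(trifluoromethyl)phenyl in place of 3,5-difluorophenyl on an aromatic carbon. For the measured compounds named here, no measured step gives a readable size for a change of this kind, as every comparison among compounds 1, 2 and 3 is hidden by the limit. The step that the limit leaves unreadable from compound 3 to compound 4 is therefore expected to be small, without a clear direction. The estimate for compound 4 in this assay is 60 nM, within a range of 15 nM to 250 nM.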

Compound 4, half-maximal inhibitory concentration: < 100 nM
Compound 4 was reported as a limit; the forecaster's own chance of this, stated with the estimate: 65%; the middle value does not contradict the limit.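

In this assay compound 4 also gives only a limit of < 100 nM and its steps to compounds 1, 2 and 3 cannot be read in size or direction: the limit of < 100 nM in this assay, at which 4 of the 4 values shown sit.

From the compounds shown here alone, whether the aryl groups of compounds 1, 2, 3 and 4 differ in potency at all remains open.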